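The source may hold more compounds than are shown below. What is called first, only, known or untested is meant among the compounds shown, and "the series" means these compounds.

Compound 1 `O=C(Nc1ncc(C(=O)O)c2nc(-c3ccco3)nn12)NC1CCCCC1`; compound 2 `CCCCC(CC)CNc1ncc(C(=O)O)c2nc(-c3ccco3)nn12`; compound 3 `COc1ccc(CNc2ncc(C(=O)O)c3nc(-c4ccco4)nn23)cc1`.

In an assay on CHO cells for displacement of a labelled ligand from adenosine receptor A1 (Homo sapiens) (a higher number here means a weaker inhibitor, a lower number a stronger inhibitor), compound 1 reaches only the assay limit, > 100000 nM. Compound 2 gives 1780 nM. Compound 3 gives 5760 nM, the higher of the two numbers, and the step of a 3.2-fold higher number from compound 2 to compound 3 (0.51 log units; beyond the scatter) is modest. Compound 1 sits at the limit of > 100000 nM in this assay, at which 1 of the 3 values shown sits, so the steps of an at least 56-fold lower number from compound 1 to compound 2 (1.74 log units; beyond the scatter) and an at least 17-fold lower number from compound 1 to compound 3 (1.23 log units; beyond the scatter) are large but open-ended. Compound 4 `O=C(O)c1cnc(NCc2ccc(C(F)(F)F)cc2)n2nc(-c3ccco3)nc12` differs from compound 3 by trifluoromethyl in place of methoxy on an aromatic carbon. Within the data shown here, no measured step swaps one substituent on that ring for another; the only step touching the benzyl arm is a 3.2-fold higher number from compound 2 to compound 3 (0.51 log units; beyond the scatter), which exchanged the whole arm for a branched chain. A step within the scatter, in either direction, is therefore expected in this assay. Compound 4 is estimated at 5000 nM, between 1500 nM and 16000 nM, a step of a 1.2-fold lower number from compound 3 to compound 4 (0.06 log units; within the scatter).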

Compound 4, inhibition constant: > 100000 nM
Compound 4: no number, only a limit; the forecaster's own chance of this, stated with the estimate: 5%; at least 20-fold (1.30 log units) between middle value and limit.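

The earlier compounds shown here exchanged only whole groups on the nitrogen, whereas here the arm stays and one group on an aromatic carbon, para to a large group, changes. In this assay, trifluoromethyl in place of methoxy gives an at least 17-fold higher number from compound 3 to compound 4 (1.23 log units; beyond the scatter), so this single position alone can decide whether a number is obtained at all. Compound 4 gives only a limit, not a number: the limit of > 100000 nM in this assay, at which 2 of the 4 values shown sit.

On these data alone, it remains open whether a chlorine, a hydroxyl or a plain hydrogen at this carbon would stay close to methoxy or fall with trifluoromethyl. As far as these compounds go, the true size of the step also stays unknown.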